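This account rests on a few compounds, and the source may have more. Where it says the series, first, only, none or still open, it means among the compounds named here.

Measured compounds:
compound 1, `Oc1cccc(-c2cc(-c3ccc(C(F)(F)F)cc3)cc(-c3cccc(O)c3)n2)c1`, 2330 nM
compound 2, `Oc1ccc(-c2cc(-c3ccccc3C(F)(F)F)cc(-c3cccc(O)c3)n2)cc1`, 3210 nM
compound 3, `Oc1ccc(-c2cc(-c3ccc(C(F)(F)F)cc3)cc(-c3cccc(O)c3)n2)cc1`, 2870 nM

These three compounds were tested in a functional assay on T47D cells (Homo sapiens) for inhibition; a higher number here means a weaker inhibitor, a lower number a stronger inhibitor. Compound 3 differs from compound 1 by the change (4-hydroxyphenyl in place of 3-hydroxyphenyl on an aromatic carbon), and the step is a 1.2-fold higher number from compound 1 to compound 3 (0.09 log units; within the scatter). Compound 3 also differs from compound 2, and that step is a 1.1-fold lower number from compound 2 to compound 3 (0.05 log units; within the scatter). Compound 2 shows the highest number of the three, but its gaps to compound 3 and compound 1 are both within the scatter, so no order among them can be read. How the cores of compound 1 and compound 2 differ is not broken down here.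

Compound 4, `Oc1ccc(-c2cc(-c3ccccc3C(F)(F)F)cc(-c3ccc(O)cc3)n2)cc1`, has not yet been measured. It differs from compound 2 by 4-hydroxyphenyl in place of 3-hydroxyphenyl on an aromatic carbon. Going by the values given here, this is the same kind of change as the one from compound 1 to compound 3, though the surroundings differ: there the place was meta to a 3-hydroxyphenyl group and meta to a 4-(trifluoromethyl)phenyl group, here it is meta to a 2-(trifluoromethyl)phenyl group and meta to a 4-hydroxyphenyl group. Because the earlier step of a 1.2-fold higher number from compound 1 to compound 3 (0.09 log units; within the scatter) stayed within the scatter, a similar small step is expected here, a 1.1-fold higher number from compound 2 to compound 4 (0.05 log units; within the scatter). For compound 4 the estimate in this assay is 3600 nM, between 1700 nM and 7500 nM.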

Compound 4, half-maximal inhibitory concentration: > 50000 nM
Compound 4: no number, only a limit (the forecaster's own chance of this, stated with the estimate: 5%); middle value at least 13-fold (1.14 log units) away from the limit.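

In this assay, compound 4 gives > 50000 nM, which is a limit of the assay and not a number: the limit of > 50000 nM in this assay, at which 1 of the 4 values shown sits.

Even so, the step is readable as an at least 15-fold higher number from compound 2 to compound 4 (1.19 log units; beyond the scatter), and 4-hydroxyphenyl in place of 3-hydroxyphenyl therefore does not carry over from the core of compound 1 to the core of compound 2: the same change on two cores in this assay, a 1.2-fold higher number (0.09 log units; within the scatter) from compound 1 to compound 3 and an at least 15-fold higher number (1.19 log units; beyond the scatter) from compound 2 to compound 4, at least 12-fold (1.10 log units) apart, beyond the scatter of two such steps

This shows that, for these two pairs, the result of the change depends on the core it is made on, but it does not show which part of the core decides this, how large the step on compound 2 really is, or how the change would behave on any other core.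

The compounds shown leave open how the series would respond if an amine or a carboxylic acid stood in place of the hydroxyl group. They also leave open the effect of a nitrile in place of the trifluoromethyl group.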